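A few compounds are considered here, and "the series" means these few. Any claim that something is new, unique, unknown or untested is made for them only; others in the source may bear on it.

Measured compounds in a functional assay on MDA-MB-231 cells (Homo sapiens) for inhibition, read by MTT assay and WST assay, with a stated time of 72 h, tested at 10 uM; on this read-out higher numbers stand for more inhibition of growth at the one concentration tested and lower numbers for less inhibition of growth:
compound 1, `O=C(Nc1ccc(Oc2ccc(-c3nccs3)cc2)cc1)Nc1cccc(C(F)(F)F)c1`, gives 64.1%
compound 2, `Cc1ccc(NC(=O)Nc2ccc(Oc3ccc(-c4nccs4)cc3)cc2)cc1`, gives 22.8%
compound 3, `O=C(Nc1ccc(Oc2ccc(-c3nccs3)cc2)cc1)Nc1ccc(F)c(Cl)c1`, gives 43.9%

Among these three, compound 2 stands lowest in this assay: compound 3 lies nearest, a step of a number 21.1 percentage points higher from compound 2 to compound 3 (beyond the scatter), and compound 1 lies furthest, a step of a number 41.3 percentage points lower from compound 1 to compound 2 (beyond the scatter). Compound 4, `Cc1ccc(NC(=O)Nc2ccc(Oc3ccc(-c4ncc[nH]4)cc3)cc2)cc1`, differs from compound 2 by 1H-imidazol-2-yl in place of 1,3-thiazol-2-yl on an aromatic carbon. For the measured compounds named here, every measured step, a number 41.3 percentage points lower from compound 1 to compound 2 (beyond the scatter), a number 20.2 percentage points lower from compound 1 to compound 3 (beyond the scatter) and a number 21.1 percentage points higher from compound 2 to compound 3 (beyond the scatter), exchanges the aryl group on the urea nitrogen and leaves the five-membered ring untouched, so no measured step bears on this change. The step is therefore expected to be a number 1.2 percentage points higher from compound 2 to compound 4 (within the scatter), not beyond the scatter in either direction. Compound 4 is estimated at 24%, within a range from 5% to 48%.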

Compound 4, percent growth inhibition at one concentration: 49.3%
For compound 4 the middle estimate is 25.3 percentage points below the measured one; measured number outside the range, above it.
By their numbers in this assay, from the lowest: compound 2; then compounds 3 and 4 (each within the scatter of the next); then compound 1.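

In this assay, the five-membered ring on the aromatic carbon para to a large group proves able to move the number: 1H-imidazol-2-yl in place of 1,3-thiazol-2-yl gives a number 26.5 percentage points higher from compound 2 to compound 4 (beyond the scatter). The aryl group on the urea nitrogen is therefore not the only place where a single change shifts growth inhibition beyond the scatter. No available evidence says which feature of the exchanged ring accounts for this step. As far as these compounds go, whether the same exchange would also raise the number with the 3-(trifluoromethyl)phenyl group of compound 1 remains open. So does how a 1,3-oxazol-2-yl or 1-methylimidazol-2-yl ring would read at this position.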